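Ketone aryl group variation across the shared core

This account rests on a few compounds, and the source may have more. Where it says the series, first, only, none or still open, it means among the compounds named here.

Measured compounds:
Compound 1 `COc1ccc(C(=O)c2sc(NC(C)C)c(C#N)c2N)cc1` gives 4130 nM in an assay for inhibition of Maternal embryonic leucine zipper kinase (Homo sapiens), read by ADP-Glo, with a stated time of 0.5 h; on this read-out lower numbers stand for stronger inhibition and higher numbers for weaker inhibition.
Compound 3 `CC(C)Nc1sc(C(=O)c2ccco2)c(N)c1C#N` gives 1350 nM in this assay.
Compound 2 `CC(C)Nc1sc(C(=O)c2ccncc2)c(N)c1C#N` reaches only the assay limit of > 5000 nM in this assay.

Compound 3 holds the lowest of the two numbers recorded in this assay; compound 1 sits higher, beyond the scatter, and compound 2 contributes only a limit (the limit of > 5000 nM in this assay, at which 1 of the 3 values shown sits).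

Compound 4 `CC(C)Nc1sc(C(=O)c2ccc(Br)s2)c(N)c1C#N` is not yet measured. It differs from compound 3 in one place: 5-bromothiophen-2-yl in place of furan-2-yl on a carbonyl carbon. Among the measured compounds shown here, the only measured step on the carbonyl substituent is an at least 3.7-fold lower number from compound 2 to compound 3 (0.56 log units; beyond the scatter), which swaps a six-membered ring for a five-membered one and leaves the six-membered ring at the limit. For the measured compounds named here, no measured step covers the exchange of one five-membered heteroaryl for another, nor the entry of bromine. With both compound 3 and compound 4 carrying a five-membered ring on the carbonyl carbon, the step of a 1.2-fold lower number from compound 3 to compound 4 (0.09 log units; within the scatter) is expected to stay within the scatter. For compound 4 the estimate in this assay is 1100 nM, with a range of 350 nM to 3500 nM.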

Compound 4, half-maximal inhibitory concentration: 122 nM
Compound 4: the middle estimate sits 9.0-fold (0.96 log units) above what was measured; measured number below the stated range.
By their numbers in this assay, from the lowest: compound 4; then compound 3; then compound 1. At a limit, above all of these: compound 2.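

The exchange of one five-membered aromatic ring for another on the carbonyl carbon is not neutral, so this position responds to more than ring size: in this assay, 5-bromothiophen-2-yl in place of furan-2-yl gives an 11-fold lower number from compound 3 to compound 4 (1.04 log units; beyond the scatter). Measured against pyridin-4-yl, the same group gives an at least 40-fold lower number from compound 2 to compound 4 (1.61 log units; beyond the scatter). That step is open-ended, because compound 2 stands at a limit: the limit of > 5000 nM in this assay, at which 1 of the 4 values shown sits.

As far as these compounds go, how the step from furan-2-yl divides between sulfur for oxygen and the entry of bromine stays open; thiophen-2-yl without bromine and 5-bromofuran-2-yl would separate the two. Also open, from the compounds shown here alone, is whether chlorine or a methyl group in place of the bromine would keep the number near that of compound 4, 122 nM.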